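This account rests on a few compounds, and the source may have more. Where it says the series, first, only, none or still open, it means among the compounds named here.

Compound 1 `C=C(C)[C@@H]1CC=C(C)/C(=N/NC(=O)Nc2nnc(-c3ccc(C)cc3)o2)C1` and compound 2 `C=C(C)[C@@H]1CC=C(C)/C(=N/NC(=O)Nc2nnc(-c3ccc(O)cc3)o2)C1` share one core. In a functional assay on the whole organism (strain Swiss albino) with Mus musculus as the target, with a stated time of 4 h (a higher number here means that more compound is needed for the effect, a lower number that less compound is needed), compound 1 gives 300 mg/kg, and in this assay compound 2 gives 300 mg/kg; the step of no change at the digits printed from compound 1 to compound 2 (within the scatter) comes from hydroxy in place of methyl on an aromatic carbon.

Compound 3 `CC(C)=CC/C=C(/C)C/C=N/NC(=O)Nc1nnc(-c2ccc(C)cc2)o1` is built on a different core; how it differs from compound 1 is not broken down here. In this assay compound 3 gives 300 mg/kg, level with compounds 1 and 2.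

Compound 4 `CC(C)=CC/C=C(/C)C/C=N/NC(=O)Nc1nnc(-c2ccc(O)cc2)o1` is to compound 3 what compound 2 is to compound 1: the difference is hydroxy in place of methyl on an aromatic carbon, the same change at the same place. Because the earlier step of no change at the digits printed from compound 1 to compound 2 (within the scatter) left the minimum effective dose unchanged, the step of no change at the digits printed from compound 3 to compound 4 (within the scatter) is expected to be of the same size. Compound 4 is therefore estimated at 300 mg/kg, likely between 150 mg/kg and 600 mg/kg.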

Compound 4, minimum effective dose: 300 mg/kg
Estimate against measurement, compound 4: no gap at the digits printed; the measured number falls inside the stated range.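

Replacing 4-methylphenyl with 4-hydroxyphenyl in this assay gives no change at the digits printed from compound 3 to compound 4 (within the scatter) and this step matches the one seen on the other core: the same change on two cores in this assay, no change at the digits printed (within the scatter) from compound 1 to compound 2 and no change at the digits printed (within the scatter) from compound 3 to compound 4, 1.0-fold (0.00 log units) apart, within the scatter of two such steps

On these two cores, then, the change carries over as a step with no visible effect on the minimum effective dose. This does not show that it would behave the same way on a third core, nor does a pair of unchanged doses test whether a step of real size would carry over from one core to another.

The compounds shown leave open how an amine, a carboxylic acid or a longer chain on the same aromatic carbon would behave in this assay. They also leave open whether any such group would give the same step on both cores.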